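This account rests on a few compounds, and the source may have more. Where it says the series, first, only, none or still open, it means among the compounds named here.

The three measured compounds share one core and differ only in what sits on the aromatic ring. Compound 3 `O=C(O)c1cc([C@H]2CC[C@]3(CC2)OOC2(O3)C3CC4CC(C3)CC2C4)ccc1O` carries a carboxy group and a hydroxy group. In a physicochemical assay for solubility, read by nephelometry, measured as kinetic solubility, with a stated time of 30 min, at pH 2.0 (on this read-out lower numbers stand for lower solubility and higher numbers for higher solubility), compound 3 gives > 100 ug/mL, which is a limit of the assay rather than a number. Compound 1 `O=C(O)COc1ccc([C@H]2CC[C@]3(CC2)OOC2(O3)C3CC4CC(C3)CC2C4)cc1C(=O)O` has a carboxymethyl on that oxygen instead of hydrogen. In this assay compound 1 gives > 100 ug/mL, again a limit. The step that the two limits leave unreadable from compound 1 to compound 3 is therefore unreadable and offers no size. Compound 2 `O=C(O)c1ccc([C@H]2CC[C@]3(CC2)OOC2(O3)C3CC4CC(C3)CC2C4)cc1` carries the carboxy group alone. In this assay compound 2 gives < 1.6 ug/mL, a limit at the low end.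

Compound 4 `O=C(O)c1cccc([C@H]2CC[C@]3(CC2)OOC2(O3)C3CC4CC(C3)CC2C4)c1` differs from compound 3 by hydrogen in place of hydroxy on an aromatic carbon. For the measured compounds named here, no measured step matches this change. Compound 2 sits at the limit of < 1.6 ug/mL in this assay, at which 1 of the 3 values shown sits. Compound 3 sits at the limit of > 100 ug/mL in this assay, at which 2 of the 3 values shown sit. Compound 4, like compound 2, keeps only the carboxy group on the ring, so it is expected to fall well below compound 3, by an at least 33-fold lower number from compound 3 to compound 4 (1.52 log units; beyond the scatter), to an estimated 3 ug/mL, with a likely range from 0.8 ug/mL to 15 ug/mL.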

Compound 4, solubility: < 1.6 ug/mL
Compound 4: only a limit was reported; the forecaster's own chance of this, stated with the estimate: 50%; middle value at least 1.8-fold (0.27 log units) away from the limit.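

In this assay, for the compounds shown here, hydrogen in place of hydroxy, ortho to a carboxy group, gives an at least 62-fold lower number from compound 3 to compound 4 (1.79 log units; beyond the scatter), so this change at this position has a step of readable size, which the earlier compounds did not offer. Hydrogen in place of carboxymethoxy at the same place gives an at least 62-fold lower number from compound 1 to compound 4 (1.79 log units; beyond the scatter), a step just as large, so the two oxygen-linked groups cannot be told apart here. Compound 4 gives a limit of the assay, not a number: the limit of < 1.6 ug/mL in this assay, at which 2 of the 4 values shown sit.

On these data alone, the step between compound 2 and compound 4 cannot be read, so what moving the carboxy group around the ring does stays open, and the true sizes of the other two steps stay open as well. Also open, as far as these compounds go, is where an amine or a methoxy group at this place would fall.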